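Ethynyl for ethyl on the cyclopropyl sulfonamide of a macrocycle

The source may hold more compounds than are shown below. What is called first, only, known or untested is meant among the compounds shown, and "the series" means these compounds.

Measured so far:
compound 1, `CCC1(S(=O)(=O)NC(=O)[C@@]23C[C@H]2/C=C\CCCCN(C)C(=O)N[C@@H](CCOc2cc(-c4nc(C(C)C)cs4)nc4c(Cl)c(OC)ccc24)C(=O)N3)CC1`: 49300 nM
compound 2, `COc1ccc2c(OCC[C@@H]3NC(=O)N(C)CCCC/C=C\[C@@H]4C[C@@]4(C(=O)NS(=O)(=O)C4CC4)NC3=O)cc(-c3ccccc3)nc2c1`: > 30000 nM

In an ADME assay on cells (Homo sapiens) for activation (a higher number here means that more compound is tolerated, a lower number that less compound is tolerated), compound 1 gives 49300 nM, the only number among the two results shown. Compound 2 sits at the limit of > 30000 nM in this assay, at which 1 of the 2 values shown sits, which is a limit of the assay and not a number. No comparison between two measured compounds is available. Compound 3, `C#CC1(S(=O)(=O)NC(=O)[C@@]23C[C@H]2/C=C\CCCCN(C)C(=O)N[C@@H](CCOc2cc(-c4nc(C(C)C)cs4)nc4c(Cl)c(OC)ccc24)C(=O)N3)CC1`, differs from compound 1 by ethynyl in place of ethyl on a saturated ring carbon. Among the measured compounds shown here, with no measured step to go by, the change is expected to bring no shift beyond the scatter in this assay, so compound 3 is estimated at 45000 nM, between 20000 nM and 100000 nM, an expected step of a 1.1-fold lower number from compound 1 to compound 3 (0.04 log units; within the scatter).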

Compound 3, half-maximal cytotoxic concentration: 26300 nM
The estimate for compound 3 lay 1.7-fold (0.23 log units) above the measured number, and the stated range covers the measured number.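

In this assay, among the compounds shown here, the first readable step at this position, ethynyl in place of ethyl on a saturated ring carbon, is a 1.9-fold lower number from compound 1 to compound 3 (0.27 log units; within the scatter) and so does not separate the two compounds. On this three-membered ring, then, a triple bond outside aromatic rings in the two-carbon group leaves the two results indistinguishable. Nothing shown gives a cause for this step. On these data alone, whether a longer chain, an amine or a carboxylic acid at this carbon would move the number stays open. So does whether this exchange would read the same on another core.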